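This account rests on a few compounds, and the source may have more. Where it says the series, first, only, none or still open, it means among the compounds named here.

Measured so far:
- compound 1, `CO[C@H]1O[C@@H]([C@H](N=[N+]=[N-])C(=O)OCc2ccccc2)[C@@H](OCc2ccccc2)[C@@]2(OCc3ccccc3)[C@@H](OCc3ccccc3)CO[C@@H]12`: 73.9%
- compound 2, `CO[C@H]1O[C@@H]([C@@H](N=[N+]=[N-])C(=O)OCc2ccccc2)[C@@H](OCc2ccccc2)[C@@]2(OCc3ccccc3)[C@@H](OCc3ccccc3)CO[C@@H]12`: 63.6%
- compound 3, `CC(=O)Nc1nc(Cl)c2c(ncn2[C@@H]2O[C@@H]([C@H](N=[N+]=[N-])C(=O)OCc3ccccc3)[C@@H](OCc3ccccc3)[C@@]3(OCc4ccccc4)[C@@H](OCc4ccccc4)CO[C@@H]23)n1`: 46.9%

In an ADME assay on A549 cells (Homo sapiens) for cytotoxicity, read by MTT assay, with a stated time of 24 h, tested at 20 ug/mL (on this read-out higher numbers stand for a weaker effect at the one concentration tested and lower numbers for a stronger effect), compound 3 stands lowest of the three numbers; its nearest neighbour is compound 2 and compound 1 lies furthest from it, and both gaps to compound 3 are beyond the scatter. Within the data shown here, the single step between measured compounds that differ in one place is a number 10.3 percentage points lower from compound 1 to compound 2 (beyond the scatter), which rests on the fact that one of compounds 1 and 2 is drawn with a defined configuration and the other without, at the place where they differ and concerns a configuration only, not the exchange of a group.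

Compound 4, `COC(=O)[C@@H](N=[N+]=[N-])[C@@H]1O[C@@H](n2cnc3nc(NC(C)=O)nc(Cl)c32)[C@@H]2OC[C@H](OCc3ccccc3)[C@]2(OCc2ccccc2)[C@@H]1OCc1ccccc1`, remains to be measured in this assay. Against compound 3 it shows (hydrogen in place of phenyl on a saturated chain carbon bound to an oxygen next to a carbonyl group), read one bond further out as benzyl to methyl and benzyloxycarbonyl to methoxycarbonyl. Among the measured compounds shown here, no measured step bears on this change: the only step available is a change of configuration and says nothing about a phenyl removed at this place. With nothing in the measured steps pointing either way, no step beyond the scatter is expected in this assay, and the estimate stays near compound 3. The step expected from the change is a number 5.1 percentage points higher from compound 3 to compound 4 (within the scatter). Compound 4 is estimated at 52%, with a range from 35% to 70%.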

Compound 4, a percentage reported as activity, at one concentration (the size of the read-out at that concentration, not a potency): 40.8%
Beside the measured number, compound 4's estimate is 11.2 percentage points above it; low and high end bracket the measured number.
By their numbers in this assay, from the lowest: compounds 4 and 3 (each within the scatter of the next); then compound 2; then compound 1.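

In this assay, exchanging benzyloxycarbonyl for methoxycarbonyl gives a number 6.1 percentage points lower from compound 3 to compound 4 (within the scatter) and leaves the two compounds indistinguishable on this read-out. A phenyl on a saturated chain carbon bound to an oxygen next to a carbonyl group, with its six-membered aromatic ring of carbon only, can therefore be replaced by hydrogen without a step beyond the scatter, at least on the core of compound 3. Among these compounds, this is the first reading on the ester group itself, as the earlier step concerned a configuration only and no group was exchanged. Nothing at hand bears on why this exchange gives so small a step.

As far as these compounds go, whether the ester is needed at all stays open: a carboxylic acid or a primary amide in place of methoxycarbonyl would test this, and an ethyl or a longer chain in place of methyl would fill the range between methyl and benzyl. Also open, from the compounds shown here alone, is whether a change of configuration like that between compound 1 and compound 2 carries over to compound 4.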